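The compounds below may be only part of what the source reports. "The series", "measured", "known", "first", "only" and "open" are said of these compounds alone.

Compound 1 `O=C1C=CC(=O)C(c2cc(-c3ccc(C(=O)N4CCC(C(F)(F)F)CC4)s3)on2)=C1` — > 30000 nM
Compound 2 `COc1ccc(OC)c(-c2cc(-c3ccc(C(=O)N4CCC(C(F)(F)F)CC4)s3)on2)c1` — > 30000 nM
Compound 3 `COc1ccc(OC)c(-c2cc(-c3ccc(C(=O)N4CCCC4)s3)on2)c1` — > 30000 nM

In a functional assay on PC-3 cells (Homo sapiens) for cytotoxicity, read by XTT assay, with a stated time of 72 h (a lower number here means a stronger inhibitor, a higher number a weaker inhibitor), compound 1 reaches only a limit of the assay, not a number. The same holds for compound 2 and for compound 3, so that the limit of > 30000 nM in this assay, at which 3 of the 3 values shown sit, describes the whole measured set. The two steps that join these compounds, a step that the two limits leave unreadable from compound 1 to compound 2 and a step that the two limits leave unreadable from compound 2 to compound 3, therefore leave no readable size or direction.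

Compound 4 `O=C1C=CC(=O)C(c2cc(-c3ccc(C(=O)NCC4CC4)s3)on2)=C1` differs from compound 1 in one place: (cyclopropylmethyl)amino in place of 4-(trifluoromethyl)piperidin-1-yl on a carbonyl carbon. The step from compound 2 to compound 3 also alters the group on the carbonyl carbon and so bears on this change, but because it ends at the limit of > 30000 nM in this assay, at which 3 of the 3 values shown sit, it gives no measure of how much such a change can move the read-out. No step beyond the scatter is therefore expected; the estimate for compound 4 is that it will again sit at the limit, with a value of about 40000 nM, between 10000 nM and 150000 nM, so that the expected step is a step that the limit leaves unreadable from compound 1 to compound 4.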

Compound 4, half-maximal inhibitory concentration: > 30000 nM
Compound 4: only a limit was reported (the forecaster's own chance of this, stated with the estimate: 85%); the middle value is on the limit's open side.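

Compound 4, like compound 1, reaches only a limit in this assay, so the step between these two compounds cannot be read: the limit of > 30000 nM in this assay, at which 4 of the 4 values shown sit.

The compounds shown leave open whether any change to the group on the carbonyl carbon can bring a measurable value in this assay.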